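The compounds below may be only part of what the source reports. "The series", "measured", "known", "first", "only" and "open" are said of these compounds alone.

Compound 3 `C=C(C)[C@H]1CC=C(C)[C@@]2(O)[C@@H]1[C@H](c1ccccc1Br)O[C@@H]2C(=O)OCC` stands second highest of the three numbers in a functional assay on KB3 cells (Homo sapiens) for antiproliferative activity, read by MTT assay, with a stated time of 96 h (on this read-out higher numbers stand for weaker inhibition and lower numbers for stronger inhibition), where compound 3 gives 20000 nM. Compound 1 `C=C(C)[C@H]1CC=C(C)[C@@]2(O)[C@@H]1[C@H](c1ccc(Cl)cc1Cl)O[C@@H]2C(=O)OCC` gives 3000 nM in this assay, and compound 2 `C=C(C)[C@H]1CC=C(C)[C@@]2(O)[C@@H]1[C@H](c1ccccc1Br)O[C@@H]2C(=O)OCC1CC1` gives 50000 nM. The move from compound 3 to compound 4 `C=C(C)[C@H]1CC=C(C)[C@@]2(O)[C@@H]1[C@H](c1cccc(Cl)c1Cl)O[C@@H]2C(=O)OCC` is 2,3-dichlorophenyl in place of 2-bromophenyl on a saturated ring carbon. Of the measured steps, a 6.7-fold higher number from compound 1 to compound 3 (0.82 log units; beyond the scatter) bears on it, since that step also exchanges the aryl group on the same saturated ring carbon; a 2.5-fold lower number from compound 2 to compound 3 (0.40 log units; beyond the scatter) concerns the ester only. For the measured compounds named here, no measured pair sets 2,3-dichlorophenyl against 2-bromophenyl directly, so the direction rests on compound 1 alone. A lower number in this assay is therefore expected for compound 4, a 3.3-fold lower number from compound 3 to compound 4 (0.52 log units; beyond the scatter), short of a full reversal. Compound 4 is estimated at 6000 nM in this assay, range 2000 nM to 20000 nM.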

Compound 4, half-maximal inhibitory concentration: 5000 nM
Estimate against measurement, compound 4: 1.2-fold (0.08 log units) above, within the range that was stated.
By their numbers in this assay, from the lowest: compounds 1 and 4 (each within the scatter of the next); then compound 3; then compound 2.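

For the compounds shown here, at the saturated ring carbon next to the ring oxygen, 2,3-dichlorophenyl in place of 2-bromophenyl gives a 4.0-fold lower number from compound 3 to compound 4 (0.60 log units; beyond the scatter) in this assay, so the 2,4-dichlorophenyl of compound 1 is no longer the only dichlorophenyl group with a lower number than 2-bromophenyl. The two dichlorophenyl groups are not separated, with a 1.7-fold higher number from compound 1 to compound 4 (0.22 log units; within the scatter), so this pair gives no readable preference for either chlorine pattern. Nothing at hand explains either step. Open, as far as these compounds go, is how a phenyl group with a single chlorine, or a pyridyl or aminophenyl group, would compare at this carbon.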